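Fluoro in place of nitro: from compound 1 to compound 4

This account rests on a few compounds, and the source may have more. Where it says the series, first, only, none or still open, it means among the compounds named here.

Measured so far:
compound 1 `COc1ccccc1C(=O)NCc1ccc(CNS(=O)(=O)c2ccc([N+](=O)[O-])cc2)cc1`: 100 nM
compound 2 `Cc1ccccc1C(=O)NCc1ccc(CNS(=O)(=O)c2ccc([N+](=O)[O-])cc2)cc1`: 100 nM
compound 3 `O=C(NCc1ccc(CNS(=O)(=O)c2ccc([N+](=O)[O-])cc2)cc1)c1cccnc1`: 100 nM

In an assay on MDA-MB-231 cells for displacement of a labelled ligand from C-X-C chemokine receptor type 4 (Homo sapiens), read by fluorescence and microscopy, with stated times of 10 min and 30 min (on this read-out higher numbers stand for an effect only at larger amounts of compound and lower numbers for an effect already at smaller amounts), compound 1 stands level with compounds 2 and 3. The steps of no change at the digits printed from compound 1 to compound 2 (within the scatter) and no change at the digits printed from compound 1 to compound 3 (within the scatter), like no change at the digits printed from compound 2 to compound 3 (within the scatter), all alter the group on the carbonyl carbon and none moves beyond the scatter.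

Compound 4 `COc1ccccc1C(=O)NCc1ccc(CNS(=O)(=O)c2ccc(F)cc2)cc1` differs from compound 1 by fluoro in place of nitro on an aromatic carbon. Going by the values given here, no measured step touches this position; the three steps known lie on the other end of the shared core and are flat, so they offer no direct guide to direction. With nothing pointing either way, the step of no change at the digits printed from compound 1 to compound 4 (within the scatter) is expected to stay within the scatter, though the range is kept wide. Compound 4 is therefore estimated at 100 nM, between 30 nM and 400 nM in this assay.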

Compound 4, effective concentration (reported as EC, without a stated level of effect): 100 nM
Compound 4: middle estimate and measured number agree at the digits printed; measured number inside the range.
By their numbers in this assay, from the lowest: compounds 1, 2, 3 and 4 (each within the scatter of the next).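

In this assay, going by these compounds alone, the first step at this end of the shared core, 4-nitrophenyl to 4-fluorophenyl, gives no change at the digits printed from compound 1 to compound 4 (within the scatter). In this pair, then, the nitro group is not needed for a value at this level, and the flat reading now reaches a second place on the core. Nothing available accounts for this result.

As far as these compounds go, whether an amine, a carboxylic acid or a longer chain at this position would read the same remains open. So does whether fluoro in place of nitro holds with pyridin-3-yl on the carbonyl carbon.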